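The source may hold more compounds than are shown below. What is called first, only, known or untested is meant among the compounds shown, and "the series" means these compounds.

Measured compounds:
compound 1, `Cn1c(=O)c(C(=O)Nc2ccc(Oc3ccncc3-c3cccnc3)c(F)c2)nn(-c2cccc(C(F)(F)F)c2)c1=O`, 3980 nM
compound 2, `O=C(Nc1ccc(Oc2ccncc2-c2cccnc2)c(F)c1)C1=NN(c2ccccc2C(F)(F)F)c2ccccc2S1(=O)=O`, 46 nM

Both compounds were tested in a functional assay on MDA-MB-231 cells (Homo sapiens) for cytotoxicity, read by MTT assay, with a stated time of 72 h; on this read-out higher numbers stand for weaker inhibition and lower numbers for stronger inhibition. Compound 1 gives 3980 nM, and compound 2 gives 46 nM. On these two numbers compound 2 stands lowest, and the gap between compound 1 and compound 2 is far beyond the usual scatter of repeated measurements, so compound 2 is the more potent of the pair in this assay. The two compounds share the same amide-linked fragment but differ in their core, so no single change accounts for the gap.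

Compound 3, `O=C(Nc1ccc(Oc2ccncc2-c2cccnc2)c(F)c1)C1=NN(c2cccc(F)c2)c2ccccc2S1(=O)=O`, has not yet been measured. It keeps the core of compound 2 and differs from it in one place: 3-fluorophenyl in place of 2-(trifluoromethyl)phenyl on a nitrogen on an aromatic ring in a ring. Going by the values given here, with only two measured compounds and no comparable step among them, there is no direct precedent for this change. The expectation is a moderate shift towards a higher number, beyond the scatter but well short of the gap seen with compound 1; the estimated step is a 2.8-fold higher number from compound 2 to compound 3 (0.45 log units; beyond the scatter). For compound 3 the estimate in this assay is 130 nM, with a likely range from 35 nM to 500 nM.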

Compound 3, half-maximal inhibitory concentration: 10 nM
Compound 3: middle estimate off by 13-fold (1.11 log units), on the high side, outside the stated range (below it).
By their numbers in this assay, from the lowest: compound 3; then compound 2; then compound 1.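

In this assay, placing 3-fluorophenyl instead of 2-(trifluoromethyl)phenyl on the ring nitrogen of the shared core gives a 4.6-fold lower number from compound 2 to compound 3 (0.66 log units; beyond the scatter), a modest step but one that lies beyond the scatter. Going by these compounds alone, this is the first comparison here that differs in one place, and it shows that this position responds to a change of its aryl group and that the trifluoromethyl group is not needed for a low number on this core. The step cannot say which part of the change matters, since the substituent on the phenyl ring changes in both kind and location at once, and nothing measured here explains the direction of the step.

The compounds shown leave those two parts unseparated: 2-fluorophenyl on the same core would isolate the kind of substituent from its location, while plain phenyl would show whether any substituent is needed at all. From the compounds shown here alone, it also remains open whether a quite different group here, such as 3-aminophenyl or a pyridine ring, would fit the same trend, and whether the step would carry over to the core of compound 1.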